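Swapping a para tert-butyl for fluoro on the sulfonamide aryl

The compounds below may be only part of what the source reports. "The series", "measured", "known", "first", "only" and "open" are said of these compounds alone.

Among the compounds with values here, compound 3 `CC(C)(C)c1ccc(NS(=O)(=O)c2cccc(CCCCCCNC(=O)/C=C/c3cccnc3)c2)cc1` gives 9.47 nM in an assay on isolated protein for inhibition of Nicotinamide phosphoribosyltransferase (Homo sapiens), read by WST assay, with stated times of 60 min, 5 min and 30 min, in the presence of a further agent that is not named here (a higher number here means a weaker inhibitor, a lower number a stronger inhibitor), the second highest of the three numbers measured so far. Compound 1 `Cc1ccccc1NS(=O)(=O)c1cccc(CCCCCCNC(=O)/C=C/c2cccnc2)c1` gives 5.08 nM, and the two lie within the scatter of each other, while compound 2 `CCc1ccc(NS(=O)(=O)c2cccc(CCCCCCNC(=O)/C=C/c3cccnc3)c2)cc1` gives 31.5 nM, a gap from compound 3 that is beyond the scatter. Compound 4 `O=C(/C=C/c1cccnc1)NCCCCCCc1cccc(S(=O)(=O)Nc2ccc(F)cc2)c1` has not yet been measured; it differs from compound 3 by fluoro in place of tert-butyl on an aromatic carbon. The step that bears most directly on this change is a 3.3-fold lower number from compound 2 to compound 3 (0.52 log units; beyond the scatter), where the group with fewer atoms on that aromatic carbon gave the higher number. The steps of a 6.2-fold higher number from compound 1 to compound 2 (0.79 log units; beyond the scatter) and a 1.9-fold higher number from compound 1 to compound 3 (0.27 log units; within the scatter) fit the same picture. Fluoro has fewer atoms still, so compound 4 is expected to show a higher number than compound 3 because of a 3.3-fold lower number from compound 2 to compound 3 (0.52 log units; beyond the scatter), a step of about a 3.7-fold higher number from compound 3 to compound 4 (0.57 log units; beyond the scatter). Compound 4 is therefore estimated at 35 nM, within a range from 10 nM to 120 nM.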

Compound 4, half-maximal inhibitory concentration: 9.2 nM
Estimate against measurement, compound 4: 3.8-fold (0.58 log units) above; measured number below the stated range.
By their numbers in this assay, from the lowest: compounds 1, 4 and 3 (each within the scatter of the next); then compound 2.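

Swapping the four heavy atoms of tert-butyl for a single fluorine leaves no difference that this assay can resolve (a 1.0-fold lower number from compound 3 to compound 4 (0.01 log units; within the scatter)), so the number at this position does not simply rise as the group gets smaller. Compound 2 is the one that goes against a single trend in size, since fluoro also stands clear of ethyl (a 3.4-fold lower number from compound 2 to compound 4 (0.53 log units; beyond the scatter)), while the 4-fluorophenyl and 2-methylphenyl compounds cannot be told apart (a 1.8-fold higher number from compound 1 to compound 4 (0.26 log units; within the scatter)). Nothing measured here accounts for why ethyl stands apart from the other groups.

Going by these compounds, whether that higher number is peculiar to ethyl or is shared by propyl or methoxy on the same carbon remains open. Also open, on these data alone, is whether an amine or a carboxylic acid there would keep the number as low.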